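The compounds below may be only part of what the source reports. "The series", "measured", "known", "first", "only" and "open" are said of these compounds alone.

Measured compounds in the series:
- compound 1, `CCCSc1nc(N/N=C/c2ccc(C)cc2)c2nnn(Cc3ccccc3)c2n1`. In a functional assay on ECa-109 cells (Homo sapiens) for antiproliferative activity, read by MTT assay, with a stated time of 72 h (on this read-out lower numbers stand for stronger inhibition and higher numbers for weaker inhibition), compound 1 gives > 64000 nM, which is a limit of the assay and not a number.
- compound 2, `CCCSc1nc(N/N=C/c2ccccc2Cl)c2nnn(Cc3ccccc3)c2n1`. In this assay compound 2 gives 6180 nM.
- compound 3, `CCCSc1nc(N/N=C/c2cccc(Cl)c2)c2nnn(Cc3ccccc3)c2n1`. In this assay compound 3 gives > 64000 nM, again a limit of the assay.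

Compound 3 therefore stands at the upper edge of what this assay reports, and it shares that position with one other compound (the limit of > 64000 nM in this assay, at which 2 of the 3 values shown sit). Only compound 2 returns a readable number. The measured steps are an at least 10-fold lower number from compound 1 to compound 2 (1.01 log units; beyond the scatter) and an at least 10-fold higher number from compound 2 to compound 3 (1.01 log units; beyond the scatter), while a step that the two limits leave unreadable from compound 1 to compound 3.

Compound 4, `CCCSc1nc(N/N=C/c2c[nH]c3ccccc23)c2nnn(Cc3ccccc3)c2n1`, differs from compound 3 by 1H-indol-3-yl in place of 3-chlorophenyl on a carbon with a double bond to nitrogen. For the measured compounds named here, no measured step touches an indol-3-yl group, so the two large steps above, both of which turn on a chlorine substituent moving around the ring, give no direct guide. What they do show is that compound 3 sits at a limit, so any step from compound 3 to compound 4 can only be read as a lowering or as no readable change. With a fused bicyclic donor-bearing group entering, a moderate lowering is estimated, but the expected outcome for compound 4 remains near the limit: the estimate for compound 4 is 30000 nM, with a range from 5000 nM to 64000 nM, which means an expected step of an at least 2.1-fold lower number from compound 3 to compound 4 (0.32 log units; beyond the scatter).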

Compound 4, half-maximal inhibitory concentration: 8690 nM
Compound 4: the middle estimate sits 3.5-fold (0.54 log units) above what was measured; the measured number falls inside the stated range.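

In this assay, the carbon with a double bond to nitrogen now carries a second group that returns a readable number. 1H-indol-3-yl has no chlorine, and 2-chlorophenyl is no longer the only group shown to leave the limit. Against the two limit compounds, the change gives an at least 7.3-fold lower number from compound 3 to compound 4 (0.86 log units; beyond the scatter) and an at least 7.3-fold lower number from compound 1 to compound 4 (0.86 log units; beyond the scatter), and each of these is read against a limit, so only a minimum size is known. Against the one other readable group, the change gives a 1.4-fold higher number from compound 2 to compound 4 (0.15 log units; within the scatter), so 1H-indol-3-yl and 2-chlorophenyl cannot be told apart here, even though the former brings a five-membered aromatic ring with a hydrogen-bond donor.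

Going by these compounds, compound 1 and compound 3 stay at a limit of the assay, which leaves their true distance from compound 4 open: the limit of > 64000 nM in this assay, at which 2 of the 4 values shown sit. It also remains open whether the ring hydrogen-bond donor of 1H-indol-3-yl matters at this position, which a hydroxyl or an amine on a phenyl ring, or an indole carrying a methyl group on its ring nitrogen, could help to test.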